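Halogenated benzyl groups against a methyl on the shared core

The compounds below may be only part of what the source reports. "The series", "measured", "known", "first", "only" and "open" are said of these compounds alone.

Compound 1 `OC[C@H]1O[C@@H](n2cnc3c(NCc4ccccc4F)ncnc32)[C@H](O)[C@@H]1O` and compound 2 `OC[C@H]1O[C@@H](n2cnc3c(NCc4ccccc4Cl)ncnc32)[C@H](O)[C@@H]1O` carry a halogen on the benzyl arm of the shared core, and both are measured in a functional assay on HL-60 cells (Homo sapiens) for antiproliferative activity, with a stated time of 72 h; a higher number here means a weaker inhibitor, a lower number a stronger inhibitor: compound 1 gives 3200 nM, and compound 2 gives 1600 nM, a change of a 2.0-fold lower number from compound 1 to compound 2 (0.30 log units; within the scatter). Compound 3 `Cc1ccc(CNc2ncnc3c2ncn3[C@@H]2O[C@H](CO)[C@@H](O)[C@H]2O)cc1` carries a 4-methylphenyl instead, and in this assay compound 3 gives only a limit of > 166000 nM, so it stands at the limit of > 166000 nM in this assay, at which 1 of the 3 values shown sits. The steps that reach compound 3 are large: an at least 51-fold higher number from compound 1 to compound 3 (1.71 log units; beyond the scatter) and an at least 100-fold higher number from compound 2 to compound 3 (2.01 log units; beyond the scatter).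

Compound 4 `OC[C@H]1O[C@@H](n2cnc3c(NCc4ccc(F)cc4Cl)ncnc32)[C@H](O)[C@@H]1O` is not yet measured. Relative to compound 3 the change is 2-chloro-4-fluorophenyl in place of 4-methylphenyl on a saturated chain carbon bound to a nitrogen on an aromatic ring. This reverses the direction of the two large steps into compound 3, with the 2-chlorophenyl of compound 2 now also carrying a fluorine. The steps from compound 1 and compound 2 into compound 3 were both well beyond the scatter, so a large drop in the number is expected for compound 4, estimated as an at least 110-fold lower number from compound 3 to compound 4 (2.04 log units; beyond the scatter). In this assay compound 4 is therefore expected to give about 1500 nM, within a range of 400 nM to 6000 nM.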

Compound 4, half-maximal inhibitory concentration: 9000 nM
Compound 4: middle estimate off by 6.0-fold (0.78 log units), on the low side; measured number above the stated range.
By their numbers in this assay, from the lowest: compounds 2 and 1 (each within the scatter of the next); then compound 4. At a limit, above all of these: compound 3.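

In this assay, adding fluoro to the 2-chlorophenyl of compound 2 gives a step that the halogen exchange between compound 1 and compound 2 did not give (the step is a 5.6-fold higher number from compound 2 to compound 4 (0.75 log units; beyond the scatter)), so a second halogen on this arm does not hold the number low. The 2-chloro-4-fluorophenyl group also compares poorly with 2-fluorophenyl (the step is a 2.8-fold higher number from compound 1 to compound 4 (0.45 log units; beyond the scatter)). It still stands far from 4-methylphenyl (the step is an at least 18-fold lower number from compound 3 to compound 4 (1.26 log units; beyond the scatter)), but that step is read against a limit for compound 3: the limit of > 166000 nM in this assay, at which 1 of the 4 values shown sits.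

As far as these compounds go, whether a methoxy group or an amine in place of that fluoro would give a similar number remains open. From the compounds shown here alone, it is also open whether the large loss with 4-methylphenyl belongs to the methyl itself, which an unsubstituted phenyl or a 4-chlorophenyl could test.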